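From tert-Butyl to Pentyl on a Shared Core

The source may hold more compounds than are shown below. What is called first, only, known or untested is meant among the compounds shown, and "the series" means these compounds.

Compound 1 `Cc1ccccc1Nc1ccc2c(c1)C(=O)N(C1CCC(=O)NC1=O)C2=O`: 2%
Compound 2 `CC(C)(C)c1ccc(Nc2cccc3c2C(=O)N(C2CCC(=O)NC2=O)C3=O)cc1`: 36%
Compound 3 `CCOC(=O)c1ccc(Nc2ccc3c(c2)C(=O)N(C2CCC(=O)NC2=O)C3=O)cc1`: 5%

In an assay on FRT-Jurkat cells for inhibition of nuclear factor NF-kappa-B complex (Homo sapiens), read by flow cytometry, with a stated time of 24 h, tested at 10 uM (a lower number here means less inhibition, a higher number more inhibition at the concentration tested (going by the name of the read-out)), compound 2 stands highest of the three numbers. Compound 3 comes nearest, lower by a gap beyond the scatter, and compound 1 sits furthest, lower still and also beyond the scatter. Compound 4 `CCCCCc1ccc(Nc2cccc3c2C(=O)N(C2CCC(=O)NC2=O)C3=O)cc1` differs from compound 2 in one place: pentyl in place of tert-butyl on an aromatic carbon. No measured pair shows this kind of change, so the direction of the step rests on no shown step. Compound 4 is expected to stay within the scatter of compound 2, with the step of a number 6 percentage points lower from compound 2 to compound 4 (within the scatter) in this assay estimated as small. Compound 4 is estimated at 30%, ranging from 10% to 50%.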

Compound 4, a percentage reported as inhibition, at one concentration (the size of the read-out at that concentration, not a potency): 23%
Compound 4: the middle estimate sits 7 percentage points above what was measured; measured number inside the range.
By their numbers in this assay, from the lowest: compounds 1 and 3 (each within the scatter of the next); then compound 4; then compound 2.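

Among these compounds, this is the first step measured on this aromatic carbon, para to a large group: in this assay, pentyl in place of tert-butyl gives a number 13 percentage points lower from compound 2 to compound 4 (beyond the scatter). The group at this place therefore bears on the read-out, and this change, though modest, lowers the number, with compound 4 still at 23%. No evidence at hand bears on why the number moves.

The compounds shown leave open how an amine, a carboxylic acid or a longer chain at this place would read. They also leave open whether a shorter chain such as propyl would fall closer to compound 2 or to compound 4.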